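A few compounds are considered here, and "the series" means these few. Any claim that something is new, unique, unknown or untested is made for them only; others in the source may bear on it.

Working notes on the series. Compound 1 `CCCN1CC[C@@]2(OC)OC(N)=C(C#N)[C@@H](c3ccc(Br)cc3)[C@@H]2C1` gives 19400 nM in a functional assay on trachea (Cavia porcellus); on this read-out higher numbers stand for weaker inhibition and lower numbers for stronger inhibition. Compound 2 `CCCN1CC[C@@]2(OC)OC(N)=C(C#N)[C@@H](c3ccc(Cl)cc3)[C@@H]2C1` gives 30300 nM in this assay. Compound 3 `COc1ccc([C@@H]2C(C#N)=C(N)O[C@]3(OC)CCN(C)C[C@@H]23)cc1` gives 23100 nM in this assay. Among the compounds with values here, the only single-point step measured so far is a 1.6-fold higher number from compound 1 to compound 2 (0.19 log units; within the scatter), a change on the aromatic ring rather than on the ring amine. Compound 3 stands second highest of the three numbers, nearest to compound 1 and furthest from compound 2, with both gaps within the scatter. Compound 1 and compound 3 differ in two places at once, so their two values are compared only as values, not read as a step.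

Compound 4 `CCCN1CC[C@@]2(OC)OC(N)=C(C#N)[C@@H](c3ccc(OC)cc3)[C@@H]2C1` differs from compound 3 by ethyl in place of hydrogen on a saturated chain carbon bound to an amine nitrogen in a ring, the same change read one bond further out as methyl to propyl. Within the data shown here, no measured step touches this position; the one step available, from compound 1 to compound 2, concerns the aromatic ring and stayed within the scatter. Compound 4 carries the aryl group of compound 3 and the propyl of compound 1 and compound 2, and all three measured numbers sit close together. The step from compound 3 to compound 4 is therefore expected to be a 1.1-fold lower number from compound 3 to compound 4 (0.02 log units; within the scatter), nothing beyond the scatter. Compound 4 is estimated at 22000 nM, with a range from 8000 nM to 60000 nM.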

Compound 4, half-maximal inhibitory concentration: 21300 nM
The estimate for compound 4 lay 1.0-fold (0.01 log units) above the measured number, within the range that was stated.
By their numbers in this assay, from the lowest: compounds 1, 4, 3 and 2 (each within the scatter of the next).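

In this assay, the change of ethyl in place of hydrogen on a saturated chain carbon bound to an amine nitrogen in a ring, read one bond further out as methyl to propyl, gives a 1.1-fold lower number from compound 3 to compound 4 (0.04 log units; within the scatter), so with the methoxy group on the aromatic ring this change stays within the scatter. Within the data shown here, with propyl held constant, methoxy in place of chloro gives a 1.4-fold lower number from compound 2 to compound 4 (0.15 log units; within the scatter) and methoxy in place of bromo gives a 1.1-fold higher number from compound 1 to compound 4 (0.04 log units; within the scatter), which places methoxy, chloro and bromo within the scatter of one another among compounds 1, 2 and 4, with no compound among them going against this. No measurement at hand offers an explanation for the size of these steps.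

Going by these compounds, whether methyl to propyl reads the same with bromo or chloro on the aromatic ring remains open, since this change has been read only with methoxy. Also open, on these data alone, is whether a longer chain such as hexyl or a benzyl group at this amine nitrogen, or a carboxylic acid on the aromatic ring, would give a step beyond the scatter.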